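The source may hold more compounds than are shown below. What is called first, only, known or untested is meant among the compounds shown, and "the series" means these compounds.

Compound 1 `O=c1c(-c2nn[nH]n2)c[nH]c2c(C(F)(F)F)cccc12`: 0.156 mg/kg
Compound 2 `COc1cccc2c(=O)c(-c3nn[nH]n3)c[nH]c12`: 0.15 mg/kg

In a functional assay on the whole organism (strain Sprague-Dawley) for inhibition, with Rattus norvegicus as the target (a higher number here means that more compound is needed for the effect, a lower number that less compound is needed), compound 2 and compound 1 give numbers that lie within the scatter of each other, so no order between them can be read. Compound 3 `CC(C)Oc1cccc2c(=O)c(-c3nn[nH]n3)c[nH]c12` differs from compound 2 by isopropyl in place of methyl on an oxygen on an aromatic ring. Among the compounds with values here, the only measured step, a 1.0-fold lower number from compound 1 to compound 2 (0.02 log units; within the scatter), concerns a different place on the core and does not bear directly on this change; no step that enlarges the group on the oxygen has been measured. Compound 3 is therefore expected near compound 2, with the step of a 1.3-fold higher number from compound 2 to compound 3 (0.12 log units; within the scatter) expected to stay within the scatter. Compound 3 is estimated at 0.2 mg/kg, with a range of 0.07 mg/kg to 0.6 mg/kg.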

Compound 3, minimum effective dose: 0.078 mg/kg
Beside the measured number, compound 3's estimate is 2.6-fold (0.41 log units) above it; the measured number falls inside the stated range.
By their numbers in this assay, from the lowest: compounds 3, 2 and 1 (each within the scatter of the next).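

In this assay, isopropyl in place of methyl on the oxygen gives a 1.9-fold lower number from compound 2 to compound 3 (0.28 log units; within the scatter) and so shows that the larger group can stand here with no step beyond the scatter. Isopropoxy in place of trifluoromethyl gives a 2.0-fold lower number from compound 1 to compound 3 (0.30 log units; within the scatter) and likewise stays within the scatter, so the three groups shown cannot be ordered. No measurement at hand accounts for these numbers.

Open, going by these compounds, is whether a longer chain on the oxygen, a cyclopropyl group or an amine in this place would also stay within the scatter.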